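Chloro-to-fluoro swap on the benzyl ring, hexylamino variant

This account rests on a few compounds, and the source may have more. Where it says the series, first, only, none or still open, it means among the compounds named here.

Measured so far:
compound 1, `CNc1nc(-c2ccccc2)nc2c1nnn2Cc1ccccc1Cl`, 191 nM
compound 2, `CNc1nc(-c2ccccc2)nc2c1nnn2Cc1ccccc1F`, 25 nM
compound 3, `CCCCCCNc1nc(-c2ccccc2)nc2c1nnn2Cc1ccccc1Cl`, 31 nM

Three compounds have a value in an assay on Cerebral cortex for displacement of a labelled ligand from adenosine receptor A1 (Bos taurus); on this read-out higher numbers stand for weaker inhibition and lower numbers for stronger inhibition. Compound 1 gives 191 nM in this assay and serves as the common reference for the other two. Compound 2 differs from it by fluoro in place of chloro on an aromatic carbon; the step is a 7.6-fold lower number from compound 1 to compound 2 (0.88 log units; beyond the scatter). Compound 3 differs from compound 1 by pentyl in place of hydrogen on a saturated chain carbon bound to a nitrogen on an aromatic ring; the step is a 6.2-fold lower number from compound 1 to compound 3 (0.79 log units; beyond the scatter). The values of compound 2 and compound 3 lie within the scatter of each other, so no order between them is drawn.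

Compound 4, `CCCCCCNc1nc(-c2ccccc2)nc2c1nnn2Cc1ccccc1F`, has not been measured in this assay. It is related to compound 3 by fluoro in place of chloro on an aromatic carbon. Within the data shown here, this is the same change as the one from compound 1 to compound 2: the leaving and entering groups are the same and the place is the same, on an aromatic carbon of a six-membered aromatic ring of carbon only, ortho to a large group. The cores of the two pairs differ by pentyl in place of hydrogen on a saturated chain carbon bound to a nitrogen on an aromatic ring, the pentyl in place of hydrogen described above.

Going by these compounds, the expected step from compound 3 to compound 4 is a 3.9-fold lower number from compound 3 to compound 4 (0.59 log units; beyond the scatter), somewhat smaller than the earlier one, because a 7.6-fold lower number from compound 1 to compound 2 (0.88 log units; beyond the scatter) was seen on a core whose starting value is higher, as compound 1 gives 191 nM, above that of compound 3, and whether the two changes add fully is unknown from these three compounds. For compound 4 the estimated value is 8 nM, expected to fall between 3 nM and 25 nM.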

Compound 4, inhibition constant: 25 nM
Beside the measured number, compound 4's estimate is 3.1-fold (0.49 log units) below it; low and high end bracket the measured number.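

Fluoro in place of chloro on the aromatic carbon does not carry its size from one core to the other: on the core bearing the longer chain it gives a 1.2-fold lower number from compound 3 to compound 4 (0.09 log units; within the scatter) in this assay, and the two steps differ: the same change on two cores in this assay, a 7.6-fold lower number (0.88 log units; beyond the scatter) from compound 1 to compound 2 and a 1.2-fold lower number (0.09 log units; within the scatter) from compound 3 to compound 4, 6.2-fold (0.79 log units) apart, beyond the scatter of two such steps

The reverse reading agrees, since pentyl in place of hydrogen on the fluoro core gives no change at the digits printed from compound 2 to compound 4 (within the scatter), and this too differs from the step on the chloro core: the same change on two cores in this assay, a 6.2-fold lower number (0.79 log units; beyond the scatter) from compound 1 to compound 3 and no change at the digits printed (within the scatter) from compound 2 to compound 4, 6.2-fold (0.79 log units) apart, beyond the scatter of two such steps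

So the two changes do not add across these four compounds, with compound 1 as the only one set apart from the others by steps beyond the scatter, but this shows neither why they fail to add nor whether the same holds on any other core or in any other assay.

Open, going by these compounds, is whether bromo, methoxy or plain hydrogen in place of the chloro would also give a step that shrinks on the longer-chain core. Also open, on these data alone, is whether an ethyl or butyl chain, a longer chain or a cyclohexyl group on the amine nitrogen would show the same loss of the fluoro step, and at what chain length that loss sets in.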